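Cyclopropyl for Methyl on Two Cores in K562 Cells

A few compounds are considered here, and "the series" means these few. Any claim that something is new, unique, unknown or untested is made for them only; others in the source may bear on it.

Of the compounds shown here, three have been measured in a functional assay on K562 cells (Homo sapiens) for inhibition, read by MTT assay, with a stated time of 48 h; a lower number here means a stronger inhibitor, a higher number a weaker inhibitor. Compound 1 `CC(=O)Nc1ccc(-c2cn([C@@H]3CN[C@H](C(=O)Nc4ccc(Cl)c(C(F)(F)F)c4)C3)nn2)cn1` carries an acetamido group and gives 8980 nM. Compound 2 `O=C(Nc1ccc(-c2cn([C@@H]3CN[C@H](C(=O)Nc4ccc(Cl)c(C(F)(F)F)c4)C3)nn2)cn1)C1CC1` differs from compound 1 by cyclopropyl in place of methyl on a carbonyl carbon; in this assay compound 2 gives 8770 nM. The step of a 1.0-fold lower number from compound 1 to compound 2 (0.01 log units; within the scatter) therefore shows no change beyond the usual scatter. Compound 3 `CC(=O)Nc1n[nH]c2cc(-c3cn([C@@H]4CN[C@H](C(=O)Nc5ccc(Cl)c(C(F)(F)F)c5)C4)nn3)ccc12` carries the same acetamido group on a different core; the difference between the two cores is not broken down here. In this assay compound 3 gives 15500 nM, and its gaps to compound 1 and to compound 2 are both within the scatter, so no ordering among these compounds can be read from the numbers.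

Compound 4 `O=C(Nc1n[nH]c2cc(-c3cn([C@@H]4CN[C@H](C(=O)Nc5ccc(Cl)c(C(F)(F)F)c5)C4)nn3)ccc12)C1CC1` is not yet measured. It differs from compound 3 by cyclopropyl in place of methyl on a carbonyl carbon, the same change as that between compound 1 and compound 2, made at the same place. Within the data shown here, the only guide is the earlier pair, where that change left the number essentially unchanged, as the step of a 1.0-fold lower number from compound 1 to compound 2 (0.01 log units; within the scatter) shows. On the core of compound 3 the change is expected to behave alike, giving an estimated step of a 1.0-fold lower number from compound 3 to compound 4 (0.01 log units; within the scatter) in this assay. Compound 4 is therefore estimated at 15000 nM in this assay, with a range from 7000 nM to 32000 nM allowing for the usual scatter. This rests on a single measured pair, so it is a cautious expectation rather than a firm rule.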

Compound 4, half-maximal inhibitory concentration: 5200 nM
Compound 4: middle estimate off by 2.9-fold (0.46 log units), on the high side; measured number below the stated range.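

In this assay, cyclopropyl in place of methyl on a carbonyl carbon gives a 3.0-fold lower number from compound 3 to compound 4 (0.47 log units; beyond the scatter), a modest step, so on the core of compound 3 this swap is followed by a real drop in the number. Set side by side, the two pairs show that the result of this change did not carry over unchanged from one core to the other: the same change on two cores in this assay, a 1.0-fold lower number (0.01 log units; within the scatter) from compound 1 to compound 2 and a 3.0-fold lower number (0.47 log units; beyond the scatter) from compound 3 to compound 4, 2.9-fold (0.46 log units) apart, beyond the scatter of two such steps. Among these compounds, they do not show why the two cores part ways, and with only one pair on each core they cannot say how the change would behave on any other core.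

The compounds shown leave open whether a longer chain such as propyl, or a bigger ring such as cyclobutyl, on the same carbonyl carbon would lower the number again on the core of compound 3 while leaving it in place on the core of compound 1. They also leave open what an amine or a carboxylic acid carried on that same carbonyl carbon would do on either core.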